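A few compounds are considered here, and "the series" means these few. Any claim that something is new, unique, unknown or untested is made for them only; others in the source may bear on it.

Compound 1 `N[C@@H]1CCCN(c2cc(NCc3ccccc3)n3nccc3n2)C1` is tested in an assay on isolated protein for inhibition of Dipeptidyl peptidase 9 (Homo sapiens); a higher number here means a weaker inhibitor, a lower number a stronger inhibitor; in this assay compound 1 gives only a limit, > 100000 nM. Compound 2 `N[C@@H]1CCCN(c2cc(Nc3cc(Cl)ccn3)n3nccc3n2)C1` also gives only a limit in this assay, > 50000 nM. The step that the two limits leave unreadable from compound 1 to compound 2 is thus unreadable, as the limit of > 100000 nM in this assay, at which 1 of the 2 values shown sits, and the limit of > 50000 nM in this assay, at which 1 of the 2 values shown sits, show. Compound 3 `Cc1ccc(Nc2cc(N3CCC[C@@H](N)C3)nc3ccnn23)c(N)c1` differs from compound 2 by 2-amino-4-methylphenyl in place of 4-chloropyridin-2-yl on a nitrogen on an aromatic ring. Among the compounds with values here, no measured step in this assay bears on this change, since both values shown are limits. Compound 3 is therefore expected, with little support, to give an estimated 20000 nM in this assay, within 2000 nM to 100000 nM. The expected at least 2.5-fold lower number from compound 2 to compound 3 (0.39 log units; beyond the scatter) rests on no measured number.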

Compound 3, half-maximal inhibitory concentration: > 100000 nM
Compound 3 ended at the assay's limit; the forecaster's own chance of this, stated with the estimate: 40%; at least 5.0-fold (0.69 log units) between middle value and limit.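

In this assay, within the data shown here, compound 1, compound 2 and compound 3 all give only limits, so no step among them can be read. The compounds shown leave open how strongly any of them inhibits, and whether the group on the nitrogen matters at all.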